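The compounds below may be only part of what the source reports. "The series", "measured", "known", "first", "only" and "open" are said of these compounds alone.

Measured in an ADME assay on HOS cells (Homo sapiens) for cytotoxicity; a lower number here means that less compound is tolerated, a higher number that more compound is tolerated:
- compound 1 `CN(Cc1nc2ccccc2n1CCCNC(=N)N)C1CCCc2cccnc21`: > 20000 nM (a limit)
- compound 2 `CN(Cc1nc2ccccc2n1CCCNC(=O)C(F)(F)F)C1CCCc2cccnc21`: 10400 nM
- compound 3 `CN(Cc1nc2cccc(C(=O)NCCCCN)c2[nH]1)C1CCCc2cccnc21`: > 20000 nM (a limit)

Compound 3 gives > 20000 nM, which is a limit and not a number. Among the compounds with values here, the values so far show (the limit of > 20000 nM in this assay, at which 2 of the 3 values shown sit).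

Compound 4 `CN(Cc1nc2cccc(CNCCN)c2[nH]1)C1CCCc2cccnc21` carries ((2-aminoethyl)amino)methyl in place of (4-aminobutyl)carbamoyl on an aromatic carbon.

Within the data shown here, the only measured step is an at least 1.9-fold lower number from compound 1 to compound 2 (0.28 log units; that floor lies within the scatter). It was made on an amine nitrogen, not on an aromatic carbon, so it bears on this change only loosely. It does suggest that a single change need not move far from the limit in this series. Among the measured compounds shown here, no measured step shows a large move to a lower number, so only a modest step or none is expected here, and a further limit is quite possible. The expected outcome in this assay is an at least 1.2-fold lower number from compound 3 to compound 4 (0.09 log units; that floor lies within the scatter), probably not clearly beyond the scatter. For compound 4 the estimated value is 16000 nM, with an expected range of 7000 nM to 30000 nM.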

Compound 4, half-maximal cytotoxic concentration: > 20000 nM
Compound 4 gave a limit, no number; the forecaster's own chance of this, stated with the estimate: 55%; middle value at least 1.2-fold (0.09 log units) away from the limit.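

In this assay, compound 3 and compound 4 are both limits and not numbers, so no step can be read between them. The compounds shown leave open whether ((2-aminoethyl)amino)methyl and (4-aminobutyl)carbamoyl on an aromatic carbon differ at all in this assay.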